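Hexyl for Isopropyl, Repeated on a Second Core

A few compounds are considered here, and "the series" means these few. Any claim that something is new, unique, unknown or untested is made for them only; others in the source may bear on it.

Of the compounds shown here, three have been measured in a functional assay on WiDr cells (Homo sapiens) for antiproliferative activity, read by sulforhodamine B assay, with a stated time of 48 h; a lower number here means a stronger inhibitor of growth, a higher number a weaker inhibitor of growth.
Compound 1, `Cc1ccc(S(=O)(=O)N2CC[C@@H](Br)C[C@@H]2CC(C)C)cc1`, gives 14000 nM.
Compound 2, `CCCCCCC[C@H]1C[C@H](Br)CCN1S(=O)(=O)c1ccc(C)cc1`, gives only a limit of the assay, > 100000 nM.
Compound 3, `Cc1ccc(S(=O)(=O)N2CCC(Cl)=CC2CC(C)C)cc1`, gives 21000 nM.

Compound 1 and compound 2 differ in one place: hexyl in place of isopropyl on a saturated chain carbon bound to a saturated ring carbon. That change gave an at least 7.1-fold higher number from compound 1 to compound 2 (0.85 log units; beyond the scatter). Compound 2 is represented by the limit of > 100000 nM in this assay, at which 1 of the 3 values shown sits. Compound 3 and compound 4, `CCCCCCCC1C=C(Cl)CCN1S(=O)(=O)c1ccc(C)cc1`, differ by the same change: hexyl in place of isopropyl on a saturated chain carbon bound to a saturated ring carbon. The difference between the core of compound 1 and the core of compound 3 is not broken down here; in this assay compound 1 and compound 3 lie within the scatter of each other. The step from compound 3 to compound 4 is expected to be of similar size, a 7.1-fold higher number from compound 3 to compound 4 (0.85 log units; beyond the scatter), because of an at least 7.1-fold higher number from compound 1 to compound 2 (0.85 log units; beyond the scatter). Compound 4 is therefore estimated at 150000 nM, within a range from 60000 nM to 500000 nM, and it is expected that the assay may again report only a limit.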

Compound 4, concentration for 50% growth inhibition: 50000 nM
Beside the measured number, compound 4's estimate is 3.0-fold (0.48 log units) above it; measured number outside the range, below it.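

In this assay, hexyl in place of isopropyl moves the number the same way on the second core as on the first, giving a 2.4-fold higher number from compound 3 to compound 4 (0.38 log units; beyond the scatter), so the direction of the change carries over between these two cores. The size of the step does not carry over, and the two cores give clearly different steps: the same change on two cores in this assay, an at least 7.1-fold higher number (0.85 log units; beyond the scatter) from compound 1 to compound 2 and a 2.4-fold higher number (0.38 log units; beyond the scatter) from compound 3 to compound 4, at least 3.0-fold (0.47 log units) apart, beyond the scatter of two such steps
On these data alone, compound 2 gives > 100000 nM, which is a limit of the assay and not a number, so the true size of the step on the first core stays unknown, and two pairs cannot show why the cores differ or whether the same direction would hold on a third core.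

The compounds shown leave open how the number changes with chain size between isopropyl and hexyl, a gap that a butyl chain would help to fill. They also leave open what a chain ending in an amine or a carboxylic acid would do on this same carbon.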